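Removing a methyl from a fused bicyclic amine in compound 1

The source may report more compounds than this note shows. Statements on the series, on what has been measured and on what is new or still open speak of the compounds shown alone.

Compound 1 `CN1CC[C@H]2CN(c3cccc4c3C[C@H](CN(C)[C@H]3CCCc5cccnc53)NC4)C[C@H]21` gives 87.3% in an ADME assay on microsomes from liver (Homo sapiens) for metabolic stability, using NADPH, with a stated time of 10 min (on this read-out lower numbers stand for a less stable compound and higher numbers for a more stable compound), the lowest of the three measured numbers. Compound 2 `CN(C[C@H]1Cc2c(cccc2N[C@H]2CC[C@H](N)CC2)CN1)[C@H]1CCCc2cccnc21` gives 100% and compound 3 `CN(C[C@H]1Cc2c(cccc2N2C[C@H]3CCN(C)[C@H]3C2)CN1)[C@H]1CCCc2cccnc21` gives 97.6% in this assay. The step of a number 12.7 percentage points higher from compound 1 to compound 2 (beyond the scatter) and the step of a number 10.3 percentage points higher from compound 1 to compound 3 (beyond the scatter) both lie beyond the scatter, while the step of a number 2.4 percentage points lower from compound 2 to compound 3 (within the scatter) does not. Compound 4 `CN(C[C@H]1Cc2c(cccc2N2C[C@H]3CNC[C@H]3C2)CN1)[C@H]1CCCc2cccnc21` differs from compound 1 in one place: a group of 8 heavy atoms (6 carbon, 2 nitrogen; 2 five-membered non-aromatic rings with 1 hetero atom each) in place of a group of 9 heavy atoms (7 carbon, 2 nitrogen; 2 five-membered non-aromatic rings with 1 hetero atom each), on an aromatic carbon. Both measured steps away from compound 1 moved upward, so a modest upward step a number 5.7 percentage points higher from compound 1 to compound 4 (within the scatter) is expected here, though the change itself is not paralleled by any measured pair and could also remain within the scatter. Compound 4 is therefore estimated at 93%, with a range from 80% to 100%.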

Compound 4, percent of the compound remaining: 86.7%
For compound 4 the middle estimate is 6.3 percentage points above the measured one, within the range that was stated.
By their numbers in this assay, from the lowest: compounds 4 and 1 (each within the scatter of the next); then compounds 3 and 2 (each within the scatter of the next).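

With the group of 8 heavy atoms on this aromatic carbon, this assay shows no separation from the group of 9 heavy atoms in one reference: a number 0.6 percentage points lower from compound 1 to compound 4 (within the scatter). The same group stands clearly apart from the other two, with a number 10.9 percentage points lower from compound 3 to compound 4 (beyond the scatter) and a number 13.3 percentage points lower from compound 2 to compound 4 (beyond the scatter). The reading therefore depends on which group of 9 heavy atoms serves as the reference, and what separates those two references is this: the fact that compounds 1 and 3 differ only in the configuration as drawn.

The compounds shown leave open whether an acetyl or an ethyl on the ring nitrogen of compound 4 would hold this level. They also leave open how the group in compound 4 would read in another drawn configuration.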